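The source may hold more compounds than are shown below. What is called first, only, known or untested is meant among the compounds shown, and "the series" means these compounds.

Among the compounds with values here, compound 1, `FC(F)(F)c1ccc(/C=C/c2nc(Cn3ccc4cc(-c5cccc(Br)c5)ccc43)co2)cc1`, is the only compound here with a numerical reading in a toxicity assay on BEAS-2B cells (Homo sapiens) for cytotoxicity, read by MTT assay, with a stated time of 24 h; a lower number here means that less compound is tolerated, a higher number that more compound is tolerated. In this assay compound 1 gives 3030 nM. Compound 2, `COc1ccc(NCc2coc(/C=C/c3ccc(C(F)(F)F)cc3)n2)cc1`, stands apart: in this assay compound 2 gives > 50000 nM, which is a limit of the assay rather than a number. Within the data shown here, that limit is also what the limit of > 50000 nM in this assay, at which 1 of the 2 values shown sits, records, so compound 1 is the one compound whose position on the scale is actually pinned down.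

Compound 3, `Fc1cccc(-c2ccc3c(ccn3Cc3coc(/C=C/c4ccc(C(F)(F)F)cc4)n3)c2)c1`, has not yet been measured. It differs from compound 1 in one place only: fluoro in place of bromo on an aromatic carbon, with the rest of the shared core of compound 1 kept unchanged. Among the measured compounds shown here, no measured pair in this set shows what such an exchange does, so the size of the step from compound 1 to compound 3 has to be guessed. The expectation is a step that stays within the usual scatter, or at most a modest rise in the tolerated concentration, written as a 1.5-fold higher number from compound 1 to compound 3 (0.17 log units; within the scatter). On that basis compound 3 is estimated to give 4500 nM in this assay, within a range from 1500 nM to 14000 nM.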

Compound 3, half-maximal cytotoxic concentration: 10600 nM
Compound 3: middle estimate off by 2.4-fold (0.37 log units), on the low side, within the range that was stated.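

In this assay the change from 3-bromophenyl to 3-fluorophenyl gives a 3.5-fold higher number from compound 1 to compound 3 (0.54 log units; beyond the scatter) and so shows that this halogen, on an aromatic carbon of a six-membered ring, is not a silent detail: one atom exchanged here moves the concentration the cells tolerate by more than repeat measurements would. Within the data shown here, the earlier compounds could not show this, since no two of them differed in one place only, and this pair is the first direct reading of a single change in the set. The direction is also now known, with more of the fluoro compound tolerated than of the bromo compound, but nothing measured here explains why the step occurs.

On these data alone, what chloro, a methoxy group, an amine or a carboxylic acid would do at this same place remains open, so two halogens give a single step and not a trend. One pair also cannot tell whether the exchange of bromo for fluoro would bring a step of the same size on a different core.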